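This account rests on a few compounds, and the source may have more. Where it says the series, first, only, none or still open, it means among the compounds named here.

In a functional assay on HT-29 cells (Homo sapiens) for antiproliferative activity, read by MTT assay, with a stated time of 72 h (on this read-out lower numbers stand for stronger inhibition and higher numbers for weaker inhibition), compound 1, `CCn1ccnc1-c1cc(OC)c(OC)c(OC)c1`, gives > 100000 nM, which is a limit of the assay and not a number. Compound 2, `CCCn1ccnc1-c1cc(OC)c(OC)c(OC)c1`, gives > 100000 nM, also a limit. Compound 3, `COc1cc(-c2nccn2Cc2ccccc2)cc(OC)c1OC`, gives > 100000 nM, again a limit. Compound 3 therefore has no measured potency of its own and stands with the other two at the limit of > 100000 nM in this assay, at which 3 of the 3 values shown sit.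

The change under study turns compound 3 into compound 4, `COc1cccc(-n2ccnc2-c2cc(OC)c(OC)c(OC)c2)c1`, with 3-methoxyphenyl in place of benzyl on an aromatic nitrogen.

For the measured compounds named here, three measured steps bear on this change, since each swaps the group on that same nitrogen: a step that the two limits leave unreadable from compound 1 to compound 2, a step that the two limits leave unreadable from compound 1 to compound 3 and a step that the two limits leave unreadable from compound 2 to compound 3. None has a readable size, so they offer no measure for the new step. None of the three earlier compounds carries 3-methoxyphenyl on that nitrogen. Any real number for compound 4 would mean stronger inhibition in this assay, though a further limit remains quite possible. The expected change is an at least 12-fold lower number from compound 3 to compound 4 (1.09 log units; beyond the scatter), a rough estimate toward stronger inhibition. For compound 4 the estimated value is 8000 nM, with an expected range from 300 nM to 100000 nM.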

Compound 4, half-maximal inhibitory concentration: 18900 nM
Estimate against measurement, compound 4: 2.4-fold (0.37 log units) below; low and high end bracket the measured number.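

In this assay, for the compounds shown here, putting 3-methoxyphenyl in place of benzyl on the aromatic nitrogen gives the first real number in this set, with an at least 5.2-fold lower number from compound 3 to compound 4 (0.72 log units; beyond the scatter). The comparisons with the plain chains point the same way, with an at least 5.2-fold lower number from compound 2 to compound 4 (0.72 log units; beyond the scatter) for 3-methoxyphenyl in place of propyl and an at least 5.2-fold lower number from compound 1 to compound 4 (0.72 log units; beyond the scatter) for 3-methoxyphenyl in place of ethyl, so the group on this nitrogen can change the read-out, something the steps among compound 1, compound 2 and compound 3 could not show, as none of them can be read. All three new sizes are only minimum sizes, and the true gaps remain unknown because the starting compound in each step sits at a limit of the assay and not at a number: the limit of > 100000 nM in this assay, at which 3 of the 4 values shown sit.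

The swap from benzyl to 3-methoxyphenyl changes two things at once, removing the chain carbon that links the ring to the nitrogen and adding a methoxy group, and the compounds shown do not separate these two changes. Going by these compounds, how a plain phenyl on that nitrogen would read remains open, as does a phenyl ring carrying an amine in place of the methoxy group.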